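This account rests on a few compounds, and the source may have more. Where it says the series, first, only, none or still open, it means among the compounds named here.

Working notes on the series

The shared core is that of compound 1 `CC(=O)OC(C)n1cnc2c(Cl)nc(N)nc21`. In a functional assay on SW-620 cells (Homo sapiens) for inhibition (a higher number here means a weaker inhibitor, a lower number a stronger inhibitor), compound 1 gives no number but only a limit, > 500000 nM, the limit (the limit of > 500000 nM in this assay, at which 1 of the 3 values shown sits). Compound 2 `CC(=O)OC(C)n1cnc2c(Cl)nc(F)nc21` gives 8900 nM in this assay. Compound 3 `CC(=O)OC(C)n1cnc2c(S)nc(N)nc21` gives 160 nM in this assay, the lowest of the two numbers measured, with compound 2 the nearest; the step of an at least 3100-fold lower number from compound 1 to compound 3 (3.49 log units; beyond the scatter) separates it from the limit of compound 1.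

Compound 4 `CC(=O)OC(C)n1cnc2c(S)nc(F)nc21` is not yet measured. It differs from compound 3 by fluoro in place of amino on an aromatic carbon. The same exchange is already seen once in the series, an at least 56-fold lower number from compound 1 to compound 2 (1.74 log units; beyond the scatter), a large step. The starting value of compound 1 is a limit, and the true size of that step is open. On that basis a step of similar direction and size is expected in this assay, a 16-fold lower number from compound 3 to compound 4 (1.20 log units; beyond the scatter), with wide uncertainty. For compound 4 the estimate in this assay is therefore 10 nM, expected between 1.5 nM and 80 nM.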

Compound 4, half-maximal inhibitory concentration: > 500000 nM
Compound 4 gave a limit, no number; the forecaster's own chance of this, stated with the estimate: 5%; middle value at least 50000-fold (4.69 log units) from the limit.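

Fluoro in place of amino, on the aromatic carbon between two ring nitrogen atoms, has no single direction in this assay: with sulfanyl on the core it gives an at least 3100-fold higher number from compound 3 to compound 4 (3.49 log units; beyond the scatter), the reverse of what it gives with chloro: the same change on two cores in this assay, an at least 56-fold lower number (1.74 log units; beyond the scatter) from compound 1 to compound 2 and an at least 3100-fold higher number (3.49 log units; beyond the scatter) from compound 3 to compound 4, at least 170000-fold (5.24 log units) apart, beyond the scatter of two such steps

Sulfanyl in place of chloro is equally tied to its partner group, giving an at least 56-fold higher number from compound 2 to compound 4 (1.74 log units; beyond the scatter) with fluoro, the reverse of what it gives with amino: the same change on two cores in this assay, an at least 3100-fold lower number (3.49 log units; beyond the scatter) from compound 1 to compound 3 and an at least 56-fold higher number (1.74 log units; beyond the scatter) from compound 2 to compound 4, at least 170000-fold (5.24 log units) apart, beyond the scatter of two such steps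

Compound 4 gives only a limit, > 500000 nM, so both new steps are bounds and the pairing of sulfanyl with amino in compound 3 stands out among the four compounds: the limit of > 500000 nM in this assay, at which 2 of the 4 values shown sit.

From the compounds shown here alone, how far compound 1 and compound 4 lie past the limit remains open. Also open, going by these compounds, is whether a methylamino or hydroxyl group in place of amino, alongside sulfanyl, would keep the value of compound 3.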